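A New Aryl Group on the Sulfonyl Sulfur

A few compounds are considered here, and "the series" means these few. Any claim that something is new, unique, unknown or untested is made for them only; others in the source may bear on it.

Of the compounds shown here, three built on one shared core have been measured in a functional assay on CHO cells for positive allosteric modulation of muscarinic acetylcholine receptor M5 (Homo sapiens), read by calcium flux; a lower number here means a smaller maximal response, a higher number a larger maximal response. Compound 1 `CCN(Cc1ccccc1)C(=O)C1CCN(S(=O)(=O)c2ccc(OC)cc2)CC1` gives 84%. Compound 2 `CCN(Cc1ccccc1)C(=O)C1CCN(S(=O)(=O)c2ccc(OC)c(OC)c2)CC1` gives 57%, and compound 3 `CCN(Cc1ccccc1)C(=O)C1CCN(S(=O)(=O)c2ccc(C)s2)CC1` gives 64%. Among these three numbers compound 3 stands second highest: the step of a number 7 percentage points higher from compound 2 to compound 3 (within the scatter) lies within the scatter, while the step of a number 20 percentage points lower from compound 1 to compound 3 (beyond the scatter) lies beyond it.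

Compound 4 `CCN(Cc1ccccc1)C(=O)C1CCN(S(=O)(=O)c2ccc3[nH]ncc3c2)CC1` has not been measured. It differs from compound 3 in one place: 1H-indazol-5-yl in place of 5-methylthiophen-2-yl on a sulfonyl sulfur. Of the measured steps, a number 20 percentage points lower from compound 1 to compound 3 (beyond the scatter) bears most directly on this change, since it also exchanged the whole group on the sulfonyl sulfur, and it was a modest lowering; the step of a number 7 percentage points higher from compound 2 to compound 3 (within the scatter) exchanged the same group and stayed within the scatter. Exchanges at this position have so far moved the largest response only modestly or not at all. For compound 4 a step of about a number 1 percentage points higher from compound 3 to compound 4 (within the scatter) is expected, with no firm direction. Compound 4 is therefore estimated to reach 65%, within a range from 45% to 85%.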

Compound 4, largest response reached (reported as percent of maximum), in percent of the reference or control that the assay uses: 86%
Beside the measured number, compound 4's estimate is 21 percentage points below it; measured number outside the range, above it.
By their numbers in this assay, from the lowest: compounds 2 and 3 (each within the scatter of the next); then compounds 1 and 4 (each within the scatter of the next).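

The group on the sulfonyl sulfur can also raise the largest response: 1H-indazol-5-yl gives a number 22 percentage points higher from compound 3 to compound 4 (beyond the scatter) and a number 29 percentage points higher from compound 2 to compound 4 (beyond the scatter) in this assay. Measured against the 4-methoxyphenyl group, it gives a number 2 percentage points higher from compound 1 to compound 4 (within the scatter), so two different groups on this sulfur sit level, and 5-methylthiophen-2-yl and 3,4-dimethoxyphenyl both fall short of them. Compound 4 is the only one shown with a hydrogen-bond donor in this group, but no measurement here explains the difference.

Still open, as far as these compounds go, is whether that donor matters at all. A 1-methyl-1H-indazol-5-yl group or a 4-aminophenyl group on the same sulfur would help to separate the donor from the two-ring shape of the group.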